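Chain extension in a methoxybenzyl hydroxamate series

The source may report more compounds than this note shows. Statements on the series, on what has been measured and on what is new or still open speak of the compounds shown alone.

Measured so far in an assay on isolated protein for inhibition of protein deacetylase HDAC6 (Homo sapiens), with a stated time of 60 min, tested at 10 nM; on this read-out higher numbers stand for more inhibition at the one concentration tested (going by the name of the read-out) and lower numbers for less inhibition:
compound 1, `O=C(CCCCCCn1cc(Nc2ncc3ccn(Cc4ccc(Cl)cc4)c3n2)cn1)NO`, gives 39%
compound 2, `Cc1ccc(Cn2ccc3cnc(Nc4cnn(CCCCCCC(=O)NO)c4)nc32)cc1`, gives 38%
compound 3, `COc1ccc(Cn2ccc3cnc(Nc4cnn(CCCCCC(=O)NO)c4)nc32)cc1`, gives 46%

Compound 3 holds the highest of the three numbers, but its nearest neighbour compound 1 and its furthest neighbour compound 2 both lie within the scatter of it, so no order among the three can be read from these values. For the measured compounds named here, the one measured step, a number 1 percentage points lower from compound 1 to compound 2 (within the scatter), is a swap of methyl for chloro on an aromatic carbon and leaves the read-out unchanged within the scatter.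

Compound 4, `COc1ccc(Cn2ccc3cnc(Nc4cnn(CCCCCCC(=O)NO)c4)nc32)cc1`, differs from compound 3 by (hydroxycarbamoyl)methyl in place of hydroxycarbamoyl on a saturated chain carbon, five bonds along the chain from an aromatic nitrogen. Going by the values given here, no measured pair isolates this change: compounds 1 and 2 share the longer chain of compound 4 but carry other groups on the aromatic carbon, and their values set against that of compound 3 show only differences within the scatter. The step from compound 3 to compound 4 is therefore expected to be a number 4 percentage points lower from compound 3 to compound 4 (within the scatter), with no direction claimed beyond the scatter. Compound 4 is estimated to give 42%, in a range from 26% to 58%.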

Compound 4, a percentage reported as inhibition, at one concentration (the size of the read-out at that concentration, not a potency): 40%
Compound 4: middle estimate off by 2 percentage points, on the high side, and the stated range covers the measured number.
By their numbers in this assay, from the lowest: compounds 2, 1, 4 and 3 (each within the scatter of the next).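

For the compounds shown here, compound 4 supplies the first pair that isolates the chain change at this position, five bonds along the chain from an aromatic nitrogen. In this assay that pair gives a number 6 percentage points lower from compound 3 to compound 4 (within the scatter) for (hydroxycarbamoyl)methyl in place of hydroxycarbamoyl, so this change shows no effect that can be told from the scatter. With the longer chain held constant, methoxy joins methyl and chloro on the aromatic carbon, and both a number 2 percentage points higher from compound 2 to compound 4 (within the scatter) and a number 1 percentage points higher from compound 1 to compound 4 (within the scatter) stay equally unresolved, while no measurement offered here bears on any cause.

The compounds shown leave open whether a still longer chain, such as one ending in 5-(hydroxycarbamoyl)pentyl, would separate from these values. Also open, as far as these compounds go, is what a carboxylic acid in place of the hydroxycarbamoyl end, or an amine on the aromatic carbon, would give.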